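Swapping a ring on an amine nitrogen

The source may report more compounds than this note shows. Statements on the series, on what has been measured and on what is new or still open speak of the compounds shown alone.

Measured so far in a functional assay on HCT-116 cells (Homo sapiens) for cytotoxicity, read by MTT assay; on this read-out lower numbers stand for stronger inhibition and higher numbers for weaker inhibition:
- Compound 1 `COc1cccc(NCc2ccc(C(=O)Nc3ccccc3N)cc2)n1` gives 800 nM
- Compound 2 `COc1ccc(NCc2ccc(C(=O)Nc3ccccc3N)cc2)cn1` gives 700 nM

Going by the values given here, only two numbers exist so far, and the single measured step between them is a 1.1-fold lower number from compound 1 to compound 2 (0.06 log units; within the scatter). Among the compounds with values here, compound 2 therefore stands level with the only other measured compound, not ahead of it.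

The next molecule, compound 3 `Nc1ccccc1NC(=O)c1ccc(CNc2ncccn2)cc1`, has not yet been measured. Its difference from compound 2 is pyrimidin-2-yl in place of 6-methoxypyridin-3-yl on an amine nitrogen. In words, this puts pyrimidin-2-yl in place of 6-methoxypyridin-3-yl on an amine nitrogen.

Within the data shown here, the one measured step offers only limited guidance. Among the measured compounds shown here, it exchanged one methoxy-bearing group for another, whereas no measured compound lacks the methoxy group or carries pyrimidin-2-yl. The data therefore give no firm direction. Little shift is expected in this assay, with a slight lean towards a higher number and nothing clearly beyond the scatter.

The expected change is a 1.4-fold higher number from compound 2 to compound 3 (0.15 log units; within the scatter). In this assay, compound 3 is estimated at 1000 nM, with an expected range from 350 nM to 3000 nM.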

Compound 3, half-maximal inhibitory concentration: 2000 nM
For compound 3 the middle estimate is 2.0-fold (0.30 log units) below the measured one, and the stated range covers the measured number.
By their numbers in this assay, from the lowest: compounds 2 and 1 (each within the scatter of the next); then compound 3.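

In this assay, the earlier pair showed only that 6-methoxypyridin-2-yl and 6-methoxypyridin-3-yl on the amine nitrogen give values within the scatter of each other, so that position had not yet shown any response to the ring it carries. Pyrimidin-2-yl is the first ring here to move the number beyond the scatter, with a 2.9-fold higher number from compound 2 to compound 3 (0.46 log units; beyond the scatter) and a 2.5-fold higher number from compound 1 to compound 3 (0.40 log units; beyond the scatter), so compound 3 is the weakest of the three in this cytotoxicity read-out and the position does respond to at least this change of ring. No measurement available here explains why the number rises.

What remains open is which part of the change matters, since the swap removes the methoxy group and also replaces a ring with one hetero atom by a ring with two, and the compounds shown cannot separate these. A plain phenyl or pyridin-3-yl ring on the same amine nitrogen, or a methoxy-bearing pyrimidine, would be the kind of group that could pull these apart.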